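Aryl swaps on a shared hydrazone core in BGC-823 cells

The source may report more compounds than this note shows. Statements on the series, on what has been measured and on what is new or still open speak of the compounds shown alone.

Three compounds built on the same core were measured in a functional assay on BGC-823 cells (Homo sapiens) for cytotoxicity, read by MTT assay, with a stated time of 48 h; a lower number here means a stronger inhibitor, a higher number a weaker inhibitor. Compound 1 `O=C(CSc1nnc(-c2ccncc2)o1)N/N=C/c1ccc([N+](=O)[O-])cc1` gives 31500 nM. Compound 2 `O=C(CSc1nnc(-c2ccncc2)o1)N/N=C/c1cccc(F)c1` gives 27500 nM. Compound 3 `O=C(CSc1nnc(-c2ccncc2)o1)N/N=C/c1ccccc1F` gives 24000 nM, the lowest of the three numbers, although the gaps to the others are within the scatter: a 1.3-fold lower number from compound 1 to compound 3 (0.12 log units; within the scatter) and a 1.1-fold lower number from compound 2 to compound 3 (0.06 log units; within the scatter). The remaining step, a 1.1-fold lower number from compound 1 to compound 2 (0.06 log units; within the scatter), is likewise within the scatter.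

Compound 4 `O=C(CSc1nnc(-c2ccncc2)o1)N/N=C/c1cc(Cl)cc(Cl)c1O` has not yet been measured in this assay. It differs from compound 3 in one place: 3,5-dichloro-2-hydroxyphenyl in place of 2-fluorophenyl on a carbon with a double bond to nitrogen. Among the compounds with values here, the steps that bear on this are the three aryl swaps already measured, and none of them moved the number beyond the scatter. Within the data shown here, the entering group is larger and carries one hydrogen-bond donor and one hydrogen-bond acceptor that the leaving group lacks, but the data hold no step that shows what such a change does on this core.

Compound 4 is therefore expected to stay close to compound 3, with the estimated step of a 1.3-fold lower number from compound 3 to compound 4 (0.12 log units; within the scatter) lying within the scatter. The estimate for compound 4 in this assay is 18000 nM, with a range from 5000 nM to 60000 nM.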

Compound 4, half-maximal inhibitory concentration: 6340 nM
For compound 4 the middle estimate is 2.8-fold (0.45 log units) above the measured one, within the range that was stated.
By their numbers in this assay, from the lowest: compound 4; then compounds 3, 2 and 1 (each within the scatter of the next).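

In this assay, within the data shown here, the position on the carbon with a double bond to nitrogen had seemed indifferent to the aryl swaps among compounds 1, 2 and 3, but the 3,5-dichloro-2-hydroxyphenyl group now gives the first steps beyond the scatter on this core: a 3.8-fold lower number from compound 3 to compound 4 (0.58 log units; beyond the scatter) and a 4.3-fold lower number from compound 2 to compound 4 (0.64 log units; beyond the scatter) and also a 5.0-fold lower number from compound 1 to compound 4 (0.70 log units; beyond the scatter) in the same direction. These steps are modest, yet they make compound 4 the strongest inhibitor of the four and show that the number at this position can move when this larger aryl group, with its hydrogen-bond donor and acceptor, replaces 2-fluorophenyl, 3-fluorophenyl or 4-nitrophenyl. Nothing available explains how this change lowers the number.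

The two chlorine atoms and the hydroxyl group enter together, so the compounds shown cannot say whether one of them alone would produce the shift, as a comparison of 2-hydroxyphenyl with 3,5-dichlorophenyl on the same core could. They also leave open how this position would respond to an aryl group carrying an amine or a carboxylic acid, and whether the step would hold on a core with a different group in place of the one shared here.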